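Aryl amine variation on a shared imide core

This account rests on a few compounds, and the source may have more. Where it says the series, first, only, none or still open, it means among the compounds named here.

Of the compounds shown here, three have been measured in an assay on FRT-Jurkat cells for inhibition of nuclear factor NF-kappa-B complex (Homo sapiens), read by flow cytometry, with a stated time of 24 h, tested at 10 uM; a higher number here means more inhibition at the concentration tested (going by the name of the read-out), a lower number less inhibition. Compound 1 `COc1ccc(Nc2cccc3c2C(=O)N(C2CCC(=O)NC2=O)C3=O)cc1` gives 13%. Compound 2 `Cc1ccccc1Nc1cccc2c1C(=O)N(C1CCC(=O)NC1=O)C2=O` gives 7%, and compound 3 `CCCCCc1ccc(Nc2cccc3c2C(=O)N(C2CCC(=O)NC2=O)C3=O)cc1` gives 23%. The numbers for compound 3 and compound 1 are within the scatter of each other; compound 2 lies beyond the scatter from compound 3, and a number 6 percentage points lower from compound 1 to compound 2 (within the scatter) stays within the scatter. Within the data shown here, the one step that touches the same position as the change now in view is a number 10 percentage points higher from compound 1 to compound 3 (within the scatter), also within the scatter.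

Compound 4 `CC(=O)c1ccc(Nc2cccc3c2C(=O)N(C2CCC(=O)NC2=O)C3=O)cc1` differs from compound 3 by acetyl in place of pentyl on an aromatic carbon. Among the measured compounds shown here, the only measured precedent for exchanging the group on that aromatic carbon is the step from compound 1 to compound 3, which did not move the number beyond the scatter; nothing measured separates a group carrying a hydrogen-bond acceptor at that place from one without. The expectation for compound 4 is therefore no step beyond the scatter in this assay, with the estimated value leaning slightly toward compound 1, giving a step of a number 8 percentage points lower from compound 3 to compound 4 (within the scatter) on the estimate. Compound 4 is estimated at 15%, expected between 3% and 30%.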

Compound 4, a percentage reported as inhibition, at one concentration (the size of the read-out at that concentration, not a potency): 2%
Compound 4: middle estimate off by 13 percentage points, on the high side; the whole stated range lies above it.
By their numbers in this assay, from the lowest: compounds 4, 2, 1 and 3 (each within the scatter of the next, the first and the last beyond it).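

In this assay, the group on this aromatic carbon now produces steps beyond the scatter: a number 21 percentage points lower from compound 3 to compound 4 (beyond the scatter) and a number 11 percentage points lower from compound 1 to compound 4 (beyond the scatter), both modest, whereas the exchange of methoxy for pentyl at the same place stayed within it. Acetyl is thus separated from both pentyl and methoxy, while a number 5 percentage points lower from compound 2 to compound 4 (within the scatter) remains within the scatter, so the 4-acetylphenyl and 2-methylphenyl groups on the nitrogen are not told apart. No measurement at hand accounts for the lower numbers with acetyl.

Going by these compounds, it remains open whether the separation follows the carbonyl of acetyl or something else about that group, and a carboxylic acid, an amide or a longer ketone on the same aromatic carbon would help to tell these apart. All the numbers also come from one concentration, so the steps describe the size of inhibition at that concentration and leave potency across the series unresolved.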